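The source may report more compounds than this note shows. Statements on the series, on what has been measured and on what is new or still open speak of the compounds shown alone.

Compound 1 `CCN(c1ccc(OC)cc1)c1ncnc2occ(C)c12`: 812 nM
Compound 2 `CCc1ccc(N(C)c2ncnc3occ(C)c23)cc1`: 287 nM

Both numbers come from a functional assay on Chorioallantoic membrane (Gallus gallus, strain Leghorn), read by microscopy, with a stated time of 40 h; on this read-out lower numbers stand for stronger inhibition and higher numbers for weaker inhibition. Compound 2 has the lower number of the two, and its gap to compound 1 lies beyond the scatter. Compound 3 `Cc1coc2ncnc(N(C)c3ccc([N+](=O)[O-])cc3)c12` keeps the shared core and carries nitro in place of ethyl on an aromatic carbon, para to a large group (nitro in place of ethyl on an aromatic carbon). Going by the values given here, no measured pair shows this change alone, so the expectation is loose: a modest weakening in this assay, starting from compound 2 at 287 nM. The expected change is a 1.7-fold higher number from compound 2 to compound 3 (0.24 log units; within the scatter). For compound 3 the estimated value is 500 nM, with an expected range of 120 nM to 2000 nM.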

Compound 3, half-maximal inhibitory concentration: 1060 nM
Beside the measured number, compound 3's estimate is 2.1-fold (0.33 log units) below it, and the stated range covers the measured number.
By their numbers in this assay, from the lowest: compound 2; then compounds 1 and 3 (each within the scatter of the next).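

In this assay, nitro in place of ethyl on an aromatic carbon, para to a large group, gives a 3.7-fold higher number from compound 2 to compound 3 (0.57 log units; beyond the scatter) and so weakens inhibition by more than the usual scatter. Going by these compounds alone, this is the first comparison here of compounds that differ in one place, and it shows that the group at this position affects the result. Nothing measured here explains the loss.

Going by these compounds, what an amine or a longer chain would do at this position remains open. So does whether the same change would have a similar effect in compounds with a different substitution elsewhere.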